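Swapping the Amine-Bearing Ring at the Chain End

This account rests on a few compounds, and the source may have more. Where it says the series, first, only, none or still open, it means among the compounds named here.

Compound 1, `CCOC(=O)N1CCN(CCCOc2ccc(-c3cccc(C#N)c3)cc2)CC1`: 24000 nM
Compound 2, `N#Cc1ccc(-c2ccc(OCCCN3CCC(N)CC3)cc2)cc1`: 33900 nM

In an assay on isolated protein for binding affinity to histamine H2 receptor (Homo sapiens) (a higher number here means a weaker inhibitor, a lower number a stronger inhibitor), compound 2 gives 33900 nM, and compound 1 gives 24000 nM; the gap between them lies within the usual scatter, so the two stand level as weak binders.

Compound 3, `N#Cc1ccc(-c2ccc(OCCCN3CC[C@@H](O)C3)cc2)cc1`, differs from compound 2 in one place: 3-hydroxypyrrolidin-1-yl in place of 4-aminopiperidin-1-yl on a saturated chain carbon, three bonds along the chain from an oxygen on an aromatic ring. Within the data shown here, no measured pair shows a comparable change, so the expectation rests on the two weak values alone. Compound 3 is expected to stay in the same weak range, with a step of a 1.2-fold higher number from compound 2 to compound 3 (0.07 log units; within the scatter) that is not beyond the scatter. The estimate for compound 3 is 40000 nM, between 12000 nM and 130000 nM.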

Compound 3, inhibition constant: 17000 nM
Compound 3: middle estimate off by 2.4-fold (0.37 log units), on the high side; measured number inside the range.
By their numbers in this assay, from the lowest: compounds 3, 1 and 2 (each within the scatter of the next).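

In this assay, the five-membered 3-hydroxypyrrolidin-1-yl takes the place of the six-membered 4-aminopiperidin-1-yl with a 2.0-fold lower number from compound 2 to compound 3 (0.30 log units; within the scatter) and no step beyond the scatter. At this position on the chain, then, ring size and the amine can both change without the binding leaving the weak range seen so far. No other measurement bears on this result. Still open, from the compounds shown here alone, is whether a carboxylic acid or a longer chain here would give a step beyond the scatter. The opposite stereocentre of the 3-hydroxypyrrolidin-1-yl group also remains to be compared.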